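The source may report more compounds than this note shows. Statements on the series, on what has been measured and on what is new or still open speak of the compounds shown alone.

Measured in a functional assay on A2780 cells (Homo sapiens) for antiproliferative activity, read by resazurin assay, with a stated time of 72 h; a lower number here means a stronger inhibitor, a higher number a weaker inhibitor:
- compound 1 `CN(Cc1ccccc1Br)C(=O)c1cc2c(Cc3ccccc3)n[nH]c2cc1O`: 1200 nM
- compound 2 `CN(Cc1cccc(Cl)c1)C(=O)c1cc2c(Cc3ccccc3)n[nH]c2cc1O`: 5300 nM

Of these two, compound 2 has the higher number and is thus the weaker inhibitor in this assay. The gap between them, a 4.4-fold higher number from compound 1 to compound 2 (0.65 log units; beyond the scatter), lies beyond the usual scatter.

The next compound is compound 3 `CN(Cc1cccc(Br)c1)C(=O)c1cc2c(Cc3ccccc3)n[nH]c2cc1O`, which differs from compound 2 at one place: bromo in place of chloro on an aromatic carbon. Put simply, 3-chlorobenzyl becomes 3-bromobenzyl, with bromo in place of chloro on an aromatic carbon, meta to a large group.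

For the measured compounds named here, only one measured step bears on this swap. That step, a 4.4-fold higher number from compound 1 to compound 2 (0.65 log units; beyond the scatter), changes the halogen and also where it sits on the ring, so it cannot show what the halogen swap does alone. Going by the values given here, no measured pair compares chloro and bromo at the same place. With so little to go on, a small change is the cautious expectation, with no step beyond the scatter. The expected step is a 1.3-fold lower number from compound 2 to compound 3 (0.12 log units; within the scatter) in this assay. For compound 3 the estimated value is 4000 nM (expected range 1700 nM to 9000 nM) in this assay.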

Compound 3, half-maximal inhibitory concentration: 7100 nM
Beside the measured number, compound 3's estimate is 1.8-fold (0.25 log units) below it; measured number inside the range.
By their numbers in this assay, from the lowest: compound 1; then compounds 2 and 3 (each within the scatter of the next).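

Swapping chloro for bromo on this aromatic carbon gives a 1.3-fold higher number from compound 2 to compound 3 (0.13 log units; within the scatter) in this assay, so the identity of the halogen makes no measurable difference at this place. The earlier step changed the halogen and its place together, whereas keeping bromo and going from 2-bromophenyl to 3-bromophenyl gives a 5.9-fold higher number from compound 1 to compound 3 (0.77 log units; beyond the scatter) and so separates the two: among these compounds, the change in place alone produces a gap beyond the scatter, while the change of halogen alone does not. Nothing shown here explains the effect of the halogen's place or the lack of a clear effect from the halogen swap.

The chloro-to-bromo comparison covers only the 3-substituted benzyl group, so a 2-chlorobenzyl group would be needed to test whether the two halogens also match in the other arrangement. Going by these compounds, it also remains open how a group of a different kind on the same aromatic carbon, such as an amine or a carboxylic acid, would compare with chloro and bromo.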